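The compounds below may be only part of what the source reports. "The series", "measured", "known", "first", "only" and "open" are said of these compounds alone.

Of the compounds shown here, three built on a shared core have been measured in a functional assay on MCF7 cells (Homo sapiens) for cytotoxicity, read by sulforhodamine B assay, with a stated time of 72 h; a lower number here means a stronger inhibitor, a higher number a weaker inhibitor. Compound 1 (`O=C(Nc1ccc(Nc2ncnc3c2cnn3-c2ccccc2)cc1)Nc1ccccc1Cl`) gives 55100 nM and compound 2 (`O=C(Nc1ccc(Nc2ncnc3c2cnn3-c2ccccc2)cc1)Nc1cccc(Br)c1`) gives 36300 nM while compound 3 (`Cc1ccccc1NC(=O)Nc1ccc(Nc2ncnc3c2cnn3-c2ccc(Cl)cc2)cc1`) gives 3150 nM as the lowest of the three numbers, with its gap to each of the others beyond the scatter. Compound 4 (`O=C(Nc1ccc(Nc2ncnc3c2cnn3-c2ccc(Cl)cc2)cc1)Nc1ccccc1Cl`) differs from compound 3 by one change (chloro in place of methyl on an aromatic carbon) in which chloro replaces methyl on an aromatic carbon, so 2-methylphenyl becomes 2-chlorophenyl. For the measured compounds named here, no measured pair shows this exact swap. The nearest guide is a 1.5-fold lower number from compound 1 to compound 2 (0.18 log units; within the scatter) with 3-bromophenyl in place of 2-chlorophenyl on an amide-type nitrogen. Compound 1 also carries 2-chlorophenyl but differs from compound 4 elsewhere, so it offers no direct comparison. In this assay the estimated move is a 1.1-fold higher number from compound 3 to compound 4 (0.05 log units; within the scatter) for this swap, which means no shift beyond the scatter is expected. For compound 4 the estimated value is 3500 nM with an expected range from 1300 nM to 10000 nM on this thin evidence.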

Compound 4, half-maximal inhibitory concentration: 9050 nM
Compound 4: middle estimate off by 2.6-fold (0.41 log units), on the low side; the range from low to high includes it.
By their numbers in this assay, from the lowest: compound 3; then compound 4; then compounds 2 and 1 (each within the scatter of the next).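

In this assay, the position ortho to a large group responds to a swap of a single atom: moving from 2-methylphenyl to 2-chlorophenyl gives a 2.9-fold higher number from compound 3 to compound 4 (0.46 log units; beyond the scatter) and so costs some potency. With 2-chlorophenyl held fixed, adding a further chloro elsewhere in the molecule gives a 6.1-fold lower number from compound 1 to compound 4 (0.78 log units; beyond the scatter) and shows that this second site also matters. No measurement shown here explains either step.

The compounds shown leave open how a methoxy group, an amine or a plain hydrogen at the ortho position would compare with methyl and chloro. They also leave open whether methyl would still give the lower number than chloro if hydrogen replaced the chloro at the second site.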